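The source may report more compounds than this note shows. Statements on the series, on what has been measured and on what is new or still open speak of the compounds shown alone.

Of the compounds shown here, three built on one shared core have been measured in an assay for inhibition of Fatty-acid amide hydrolase 1 (Rattus norvegicus); a higher number here means a weaker inhibitor, a lower number a stronger inhibitor. Compound 1 `O=C(CCCCC#Cc1ccc(Cl)cc1)c1ncc(-c2ccccn2)o1` gives 20 nM. Compound 2 `O=C(CCCCC#Cc1cccc(F)c1)c1ncc(-c2ccccn2)o1` gives 3.2 nM, and compound 3 `O=C(CCCCC#Cc1cccc([N+](=O)[O-])c1)c1ncc(-c2ccccn2)o1` gives 4.8 nM. Among these three numbers compound 3 holds the second highest; its nearest neighbour is compound 2, with a gap that lies within the usual scatter, and its furthest is compound 1, which lies beyond it. Compound 4 `O=C(CCCCC#Cc1cccc(C(F)(F)F)c1)c1ncc(-c2ccccn2)o1` has not yet been measured in this assay. The change is trifluoromethyl in place of nitro on an aromatic carbon. The step that bears on it most directly is a 1.5-fold higher number from compound 2 to compound 3 (0.18 log units; within the scatter), in which the group on an aromatic carbon was swapped and the two numbers remained within the scatter of each other. The larger steps of a 6.3-fold lower number from compound 1 to compound 2 (0.80 log units; beyond the scatter) and a 4.2-fold lower number from compound 1 to compound 3 (0.62 log units; beyond the scatter) altered both the group and its place, so they speak less to this swap. The expected outcome is therefore a 1.0-fold higher number from compound 3 to compound 4 (0.02 log units; within the scatter), a step within the scatter. Compound 4 is estimated at 5 nM, with a range from 1.5 nM to 16 nM.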

Compound 4, inhibition constant: 10 nM
Estimate against measurement, compound 4: 2.0-fold (0.30 log units) below, and the stated range covers the measured number.
By their numbers in this assay, from the lowest: compounds 2 and 3 (each within the scatter of the next); then compounds 4 and 1 (each within the scatter of the next).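

In this assay, the group on this aromatic carbon now makes a measurable difference: swapping fluoro for nitro had stayed within the scatter, but trifluoromethyl gives a 2.1-fold higher number from compound 3 to compound 4 (0.32 log units; beyond the scatter) against nitro and a 3.1-fold higher number from compound 2 to compound 4 (0.49 log units; beyond the scatter) against fluoro. This position therefore does not accept every group equally, although both steps are modest and compound 4 remains a nanomolar inhibitor. Nothing shown here explains why trifluoromethyl differs from the other two groups.

A methoxy group, an amine or a carboxylic acid on this same carbon would test whether the loss seen with trifluoromethyl extends to other groups. Chloro on this carbon would also separate the effect of the group from that of its place, since compound 1 differs from compound 2 and compound 3 in both.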